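Bromo in Place of Hydrogen on Compound 2

This account rests on a few compounds, and the source may have more. Where it says the series, first, only, none or still open, it means among the compounds named here.

Measured so far in a functional assay on NCI-H1650 cells (Homo sapiens) for cytotoxicity, read by MTT assay, with a stated time of 72 h; a lower number here means a stronger inhibitor, a higher number a weaker inhibitor:
- compound 1 `COc1ccc(/C=C2\COC/C(=C\c3ccccc3F)C2=O)cc1O`: 7500 nM
- compound 2 `O=C1/C(=C/c2ccccc2)COC/C1=C\c1ccccc1F`: 9600 nM
- compound 3 `COc1cc(/C=C2\COC/C(=C\c3ccccc3F)C2=O)ccc1O`: 18500 nM

Compound 2, at 9600 nM, stands within the usual scatter of both compound 1 and compound 3, so the numbers set no order around it. All three compounds share a 2-fluorophenyl side. Compound 1 and compound 3 carry further groups on the phenyl ring that is bare in compound 2, but no two of the measured compounds differ in one place only, and none carries a bromo group.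

The compound still to be read in this assay is compound 4 `O=C1/C(=C/c2ccccc2F)COC/C1=C\c1ccccc1Br`. It turns the phenyl of compound 2 into 2-bromophenyl, with bromo in place of hydrogen on an aromatic carbon. Compound 1 at 7500 nM and compound 3 at 18500 nM both lie within the scatter of compound 2 although that ring is substituted in them, so a large shift is not expected. The expected step is a 1.2-fold lower number from compound 2 to compound 4 (0.08 log units; within the scatter), a slight move toward a lower number and none beyond the scatter. For compound 4 the estimate is 8000 nM, with an expected range from 3000 nM to 20000 nM.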

Compound 4, half-maximal inhibitory concentration: 6500 nM
The estimate for compound 4 lay 1.2-fold (0.09 log units) above the measured number, and the stated range covers the measured number.
By their numbers in this assay, from the lowest: compounds 4, 1, 2 and 3 (each within the scatter of the next, the first and the last beyond it).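

For the compounds shown here, compound 2 and compound 4 form the only pair here that differs in one place, and in this assay they give a 1.5-fold lower number from compound 2 to compound 4 (0.17 log units; within the scatter) as the size of that change. Going by these compounds alone, this is the first direct reading of the ring that is bare in compound 2: bromo in place of hydrogen on an aromatic carbon, ortho to a large group, is accepted there without a shift that can be told from the scatter. The change from phenyl to 2-bromophenyl adds one heavy atom, with no hydrogen-bond donors or acceptors and no net charge, so this single pair shows that such an addition at this place leaves the cytotoxicity reading unresolved from that of compound 2, and it gives no sign of a gain or a loss. Nothing measured here bears on what lies behind this result.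

The compounds shown leave open whether an amine, a carboxylic acid or a longer chain at this same place would move the number beyond the scatter. They also leave open whether bromo would give a similar result on the core of compound 1 or compound 3, which carry further groups on that ring.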